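One added hydroxy: from compound 1 to compound 4

The source may report more compounds than this note shows. Statements on the series, on what has been measured and on what is new or still open speak of the compounds shown alone.

- compound 1 `COc1ccc(Cn2c(C(=O)O)c(CNCc3cccc(OC)c3)c3ccccc32)cc1`: 52900 nM
- compound 2 `COc1ccc(Cn2c(C(=O)O)c(CNCc3cccc(OC)c3)c3ccc(C(F)F)cc32)cc1`: > 50000 nM (a limit)
- compound 3 `COc1cccc(CNCc2c(C(=O)O)n(Cc3ccc(F)cc3)c3ccccc23)c1`: > 50000 nM (a limit)

For the measured compounds named here, in a functional assay on Bel-7402 cells (Homo sapiens) for antiproliferative activity, read by MTT assay, with a stated time of 72 h (a higher number here means a weaker inhibitor, a lower number a stronger inhibitor), compound 1 gives 52900 nM, the only true number in this small set. That number lies in the same region as the limit of > 50000 nM in this assay, at which 2 of the 3 values shown sit.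

Compound 4 `COc1ccc(Cn2c(C(=O)O)c(CNCc3ccc(O)c(OC)c3)c3ccccc32)cc1` keeps the core of compound 1 and differs from it by hydroxy in place of hydrogen on an aromatic carbon. In words, this is hydroxy in place of hydrogen on an aromatic carbon, turning 3-methoxybenzyl into 4-hydroxy-3-methoxybenzyl.

Two measured steps start from compound 1, a step that the limit leaves unreadable from compound 1 to compound 2 and a step that the limit leaves unreadable from compound 1 to compound 3. Neither has a readable size, and neither alters the 3-methoxybenzyl group, so they give no measure for this change. Going by the values given here, the only anchor is compound 1 at 52900 nM, and no step beyond the scatter is expected in this assay, in either direction.

The expected step is a 1.3-fold lower number from compound 1 to compound 4 (0.12 log units; within the scatter). For compound 4 the estimated value is 40000 nM, with an expected range of 12000 nM to 80000 nM.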

Compound 4, half-maximal inhibitory concentration: > 50000 nM
Compound 4: only a limit was reported (the forecaster's own chance of this, stated with the estimate: 35%); at least 1.2-fold (0.09 log units) between middle value and limit.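

In this assay, for the compounds shown here, compound 4 gives > 50000 nM, which is a limit and not a number, and no step from compound 1 to compound 4 can be read. The compounds shown leave open what size of step, if any, hydroxy in place of hydrogen on this aromatic carbon brings: the limit of > 50000 nM in this assay, at which 3 of the 4 values shown sit.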